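The source may hold more compounds than are shown below. What is called first, only, known or untested is meant among the compounds shown, and "the series" means these compounds.

Measured so far:
Compound 1 `CC(C)CC[C@H](O)CCCCCCCCC[C@@H]1N[C@@H](CO)[C@@H]1O` gives > 2 ug/mL in a functional assay on A549 cells (Homo sapiens) for cytotoxicity (on this read-out higher numbers stand for weaker inhibition and lower numbers for stronger inhibition), which is a limit, not a number.
Compound 2 `CCCCCCCCCCCCCC[C@@H]1N[C@H](CO)[C@H]1O` gives 1.97 ug/mL in this assay.

Compound 2 holds the only number shown in this assay; the one other value is a limit (the limit of > 2 ug/mL in this assay, at which 1 of the 2 values shown sits). Compound 3 `CCCCCCCCCCCCCC[C@@H]1N[C@H](CO)[C@@H]1O` is not yet measured. Compared with compound 2, (the two compounds have the same atoms and bonds and differ only in configuration as drawn: 1 of 3 stereo elements differ; a stereocentre at a saturated ring carbon is drawn S in compound 2 and R in compound 3). Among the measured compounds shown here, no step between measured compounds is available to size this change, and none beyond the scatter is expected in either direction. Compound 3 is expected at 2.5 ug/mL, within 1 ug/mL to 6 ug/mL. The expected step is then a 1.3-fold higher number from compound 2 to compound 3 (0.10 log units; within the scatter).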

Compound 3, half-maximal inhibitory concentration: > 2 ug/mL
Compound 3: only a limit was reported (the forecaster's own chance of this, stated with the estimate: 50%); the middle value lies beyond the limit too.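

Among the compounds shown here, the change of configuration at this saturated ring carbon gives the first step for this position in this assay: an at least 1.0-fold higher number from compound 2 to compound 3 (0.00 log units; that floor lies within the scatter). Compound 3 gives > 2 ug/mL, which is a limit and not a number, so the step has a floor but no measured size. Most of the values shown in this assay are now limits: the limit of > 2 ug/mL in this assay, at which 2 of the 3 values shown sit.

As far as these compounds go, whether this change of configuration moves the read-out beyond the scatter remains open. Also open, from the compounds shown here alone, is how a carboxylic acid on the shared core, or a longer chain, would read in this assay.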